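A few compounds are considered here, and "the series" means these few. Any claim that something is new, unique, unknown or untested is made for them only; others in the source may bear on it.

Measured compounds:
compound 1 `CCCCCC(=O)Nc1ccc(S(=O)(=O)Oc2ccccc2C(C)C)cc1`: 6300 nM
compound 2 `CC(C)C(=O)Nc1ccc(S(=O)(=O)Oc2ccccc2C(C)C)cc1`: 4900 nM

In a functional assay on HT-1080 cells (Homo sapiens) for antiproliferative activity, read by sulforhodamine B assay, with a stated time of 48 h (a higher number here means a weaker inhibitor, a lower number a stronger inhibitor), compound 1 gives 6300 nM and compound 2 gives 4900 nM. For the measured compounds named here, the only step between measured compounds, a 1.3-fold lower number from compound 1 to compound 2 (0.11 log units; within the scatter), is within the scatter, so the two numbers do not separate; compound 2 stands level with compound 1, and neither can be called the stronger inhibitor on these data.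

Compound 3 `CC(C)c1ccccc1OS(=O)(=O)c1ccc(NC(=O)CCCCl)cc1` is the next member. Relative to compound 2 the change is 3-chloropropyl in place of isopropyl on a carbonyl carbon. Going by the values given here, the one measured step that bears on this position is the pentyl-to-isopropyl exchange on the same carbonyl carbon, a 1.3-fold lower number from compound 1 to compound 2 (0.11 log units; within the scatter), which stayed within the scatter despite a change in chain length and branching. Exchanging isopropyl for 3-chloropropyl is a change of the same kind at the same place, and nothing in the two measured numbers points to a direction. A step within the scatter is therefore expected, a 1.0-fold higher number from compound 2 to compound 3 (0.01 log units; within the scatter). For compound 3 the estimate in this assay is 5000 nM, with a range from 2500 nM to 10000 nM.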

Compound 3, half-maximal inhibitory concentration: 3800 nM
Compound 3: the middle estimate sits 1.3-fold (0.12 log units) above what was measured, within the range that was stated.
By their numbers in this assay, from the lowest: compounds 3, 2 and 1 (each within the scatter of the next).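

In this assay the exchange of isopropyl for 3-chloropropyl on a carbonyl carbon gives a 1.3-fold lower number from compound 2 to compound 3 (0.11 log units; within the scatter), so adding a chlorine to the chain at this position does not separate compound 3 from compound 2. The comparison with the unbranched chain, chloro in place of ethyl on a saturated chain carbon, three bonds along the chain from a carbonyl carbon, gives a 1.7-fold lower number from compound 1 to compound 3 (0.22 log units; within the scatter) and also stays unresolved, so all three compounds now read as one level, whether the chain is branched, unbranched or chlorinated. No supporting data bear on this result, and the numbers alone give no explanation for it.

The compounds shown leave open whether any group on this carbonyl carbon can move the number beyond the scatter, for example a carboxylic acid, an amine, a phenyl ring or a much longer chain. They also leave open what the chlorine contributes apart from the chain that carries it, a question that a plain propyl group at the same place would address directly.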